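This account rests on a few compounds, and the source may have more. Where it says the series, first, only, none or still open, it means among the compounds named here.

Of the compounds shown here, two have been measured so far in a functional assay on V79 cells (Cricetulus griseus), read by MTT assay, in the presence of a further agent that is not named here; a higher number here means a weaker inhibitor, a lower number a stronger inhibitor. Compound 1 (`Cn1cc(-c2nc(C(N)=O)cs2)c2c1C(=O)C=C(N)C2=O`) gives 5100 nM, and compound 2 (`CCOC(=O)c1csc(-c2cn(C)c3c2C(=O)C(OC)=CC3=O)n1`) gives 345000 nM. Compound 2 therefore has the higher number of the two, which makes it the weaker inhibitor, and the gap lies beyond the usual scatter. These two compounds differ in more than one place, so their gap cannot be traced to any single group.

Compound 3 (`COC1=CC(=O)c2c(c(-c3nc(C)cs3)cn2C)C1=O`) has not yet been measured. It differs from compound 2 in one place: methyl in place of ethoxycarbonyl on an aromatic carbon. In short, it has methyl in place of ethoxycarbonyl on an aromatic carbon. Within the data shown here, no measured pair shows what this change does on its own, so any forecast is loose. Among the measured compounds shown here, compound 2, at 345000 nM, sits far above the only other measured number, which leaves more room to fall than to rise. The expected change is a 6.9-fold lower number from compound 2 to compound 3 (0.84 log units; beyond the scatter) in this assay, a moderate move toward stronger inhibition, beyond the scatter. For compound 3 the estimated value is 50000 nM, with an expected range from 8000 nM to 250000 nM.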

Compound 3, half-maximal inhibitory concentration: 47700 nM
Compound 3: middle estimate off by 1.0-fold (0.02 log units), on the high side, within the range that was stated.
By their numbers in this assay, from the lowest: compound 1; then compound 3; then compound 2.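

In this assay, among these compounds, this pair gives the first direct reading of a single change at this position: on an aromatic carbon of a five-membered aromatic ring with 1 nitrogen and 1 sulfur, next to the ring nitrogen, methyl in place of ethoxycarbonyl gives a 7.2-fold lower number from compound 2 to compound 3 (0.86 log units; beyond the scatter) as a modest move toward stronger inhibition. The position therefore responds to the group it carries, and here ethoxycarbonyl, with 5 heavy atoms and 2 hydrogen-bond acceptors, is not required for the activity seen, since methyl, with 1 heavy atom and no hydrogen-bond acceptors, gives the lower number. No outside measurement accompanies this step, so the data record its size and direction but offer no explanation for it.

A single step cannot separate the effect of removing the ester from the effect of shrinking the group. Going by these compounds, it also remains open whether a carboxylic acid, an amine or a longer chain such as propyl at this position would fall nearer to methyl or to ethoxycarbonyl, and whether the same swap would move the number as far on a differently substituted core.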